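The compounds below may be only part of what the source reports. "The series", "measured", "known", "first", "only" and "open" are said of these compounds alone.

In a functional assay on A549 cells (Homo sapiens) for antiproliferative activity, read by CCK-8 assay, with a stated time of 72 h (a lower number here means a stronger inhibitor, a higher number a weaker inhibitor), compound 1 (`Nc1ccccc1NC(=O)c1ccc(CSc2cccc(F)c2)cc1`) is reported as "not determined" (no result reported), so it supplies no number. Compound 2 (`Nc1ccccc1NC(=O)/C=C/c1ccc(CSc2ccc(F)cc2)cc1`) gives 1190 nM and compound 3 (`Nc1ccccc1NC(=O)c1ccc(CSc2nccc(C(F)(F)F)n2)cc1`) gives 970 nM. Going by the values given here, these are the only two numbers available, and they lie within the scatter of each other, so compound 2 stands level with compound 3.

Compound 4 (`Nc1ccccc1NC(=O)/C=C/c1ccc(CSCCc2ccccc2)cc1`) departs from compound 2 at a single place: phenethyl in place of 4-fluorophenyl on a sulfur. In words, phenethyl stands in place of 4-fluorophenyl on a sulfur. Among the compounds with values here, no step between measured compounds shows what such a replacement does, so the data give no direct guide to it. The anchor for the expectation is therefore compound 2 at 1190 nM. A modest move toward a higher number in this assay is expected, possibly one that stays within the scatter. The expected change is a 1.3-fold higher number from compound 2 to compound 4 (0.10 log units; within the scatter). For compound 4 the estimated value is 1500 nM, with an expected range from 600 nM to 4000 nM.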

Compound 4, half-maximal inhibitory concentration: 1150 nM
For compound 4 the middle estimate is 1.3-fold (0.12 log units) above the measured one, within the range that was stated.
By their numbers in this assay, from the lowest: compounds 3, 4 and 2 (each within the scatter of the next).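

In this assay, going by these compounds alone, the step is a 1.0-fold lower number from compound 2 to compound 4 (0.01 log units; within the scatter), the only step between measured compounds. It shows that, on a sulfur whose other neighbour is a saturated chain carbon, phenethyl with its 8 carbon atoms can stand in place of 4-fluorophenyl with no change that this read-out can separate from the scatter, even though the fluorine is lost. No measurement shown here accounts for this outcome.

Going by these compounds, whether an amine, a carboxylic acid or a longer chain in place of phenethyl on this sulfur would also leave the number within the scatter remains open. On these data alone, it is also open whether phenethyl would give the same result on the core of compound 3, and whether an unsubstituted phenyl would match 4-fluorophenyl on the core of compound 2.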